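This account rests on a few compounds, and the source may have more. Where it says the series, first, only, none or still open, it means among the compounds named here.

Compound 1 `O=C(NCc1cn(Cc2ccccc2)nn1)c1cn(Cc2ccccc2)nn1` carries a benzyl group on each of its two ring nitrogens, and in a functional assay on B16 cells (Mus musculus) for cytotoxicity, read by MTT assay, with a stated time of 48 h (a lower number here means a stronger inhibitor, a higher number a weaker inhibitor), compound 1 gives 300 nM. Compound 2 `CCOC(=O)Cn1cc(CNC(=O)c2cn(Cc3ccccc3)nn2)nn1` differs from it by ethoxycarbonyl in place of phenyl on a saturated chain carbon bound to an aromatic nitrogen, and in this assay compound 2 gives 35000 nM. That single change produced a 120-fold higher number from compound 1 to compound 2 (2.07 log units; beyond the scatter).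

Compound 3 `O=C(Nc1cccc(-c2cn(Cc3ccccc3)nn2)c1)c1cn(Cc2ccccc2)nn1` has a different core; how its core differs from the core of compound 1 is not broken down here. In this assay compound 3 gives 4500 nM, so it sits between the other two measured compounds, a good deal weaker than compound 1 and a good deal stronger than compound 2.

Compound 4 `CCOC(=O)Cn1cc(-c2cccc(NC(=O)c3cn(Cc4ccccc4)nn3)c2)nn1` has not yet been measured. It differs from compound 3 by ethoxycarbonyl in place of phenyl on a saturated chain carbon bound to an aromatic nitrogen, the same change that separates compound 1 from compound 2, at the same kind of place. For compound 4 the expected step is a 20-fold higher number from compound 3 to compound 4 (1.30 log units; beyond the scatter), because the same change gave a 120-fold higher number from compound 1 to compound 2 (2.07 log units; beyond the scatter) on the other core. On these data alone, whether a different core carries the change to the same extent is unknown, so the expectation is held loosely. In this assay compound 4 is expected to give about 90000 nM, within a range from 15000 nM to 500000 nM, with a fair chance that only a limit is reported.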

Compound 4, half-maximal inhibitory concentration: 21000 nM
Compound 4: middle estimate off by 4.3-fold (0.63 log units), on the high side, within the range that was stated.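

In this assay, ethoxycarbonyl in place of phenyl on a saturated chain carbon bound to an aromatic nitrogen also weakens the compound on the core of compound 3, giving a 4.7-fold higher number from compound 3 to compound 4 (0.67 log units; beyond the scatter), so the change pointed the same way on both cores shown. The size of the change, however, did not carry over from one core to the other, and the two steps differ by more than their scatter allows: the same change on two cores in this assay, a 120-fold higher number (2.07 log units; beyond the scatter) from compound 1 to compound 2 and a 4.7-fold higher number (0.67 log units; beyond the scatter) from compound 3 to compound 4, 25-fold (1.40 log units) apart, beyond the scatter of two such steps. This shows that, in this series, the direction of the change held in both pairs while its size depended on the core, so a step measured on one core is a poor guide to the exact size on another; it does not show why the cores differ, and two pairs set no rule for any further core.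

The compounds shown carry only benzyl or (ethoxycarbonyl)methyl at this place, so it remains open whether a carboxylic acid, an amide or a longer chain would follow the same course on either core. On these data alone, the benzyl group on the other ring stays the same throughout, so it is also open whether an amine-bearing chain there would alter the size of the step.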